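Replacing Cyclohexylamino with Pyrrolidin-1-yl on a Shared Core

This account rests on a few compounds, and the source may have more. Where it says the series, first, only, none or still open, it means among the compounds named here.

Compound 1, `Cc1ccc(NC2=CC(=O)c3c(nc4n3[C@H]3OC[C@@H](O)[C@H]3OC4)C2=O)cc1`: 1550 nM in a functional assay on MGC-803 cells (Homo sapiens) for inhibition, read by sulforhodamine B assay; on this read-out higher numbers stand for weaker inhibition and lower numbers for stronger inhibition.
Compound 2, `O=C1C=C(NC2CCCCC2)C(=O)c2c1nc1n2[C@H]2OC[C@@H](O)[C@H]2OC1`: > 8000 nM, a limit of the assay rather than a number.
Compound 3, `O=C1C(NC2CCCCC2)=CC(=O)c2c1nc1n2[C@H]2OC[C@@H](O)[C@H]2OC1`: > 8000 nM, likewise a limit of the assay.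

Compound 2 therefore sits at the limit of > 8000 nM in this assay, at which 2 of the 3 values shown sit, so only the weakest end of its inhibition is known. The step to compound 4, `O=C1C=C(N2CCCC2)C(=O)c2c1nc1n2[C@H]2OC[C@@H](O)[C@H]2OC1`, makes a single change: pyrrolidin-1-yl in place of cyclohexylamino on a double-bonded ring carbon. Among the measured compounds shown here, no measured step covers this exact change. For the measured compounds named here, the only measured step, an at least 5.1-fold higher number from compound 1 to compound 3 (0.71 log units; beyond the scatter), shows that moving from an aromatic to a saturated ring on the amine weakened inhibition. With compound 2 already at the limit, no direction can be read with confidence, and compound 4 is expected to stay weak. The expected step is a number no higher from compound 2 to compound 4 (the limit leaves the size open). Compound 4 is estimated at 8000 nM, within a range from 2500 nM to 25000 nM.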

Compound 4, half-maximal inhibitory concentration: > 16000 nM
Compound 4 ended at the assay's limit (the forecaster's own chance of this, stated with the estimate: 60%); middle value at least 2.0-fold (0.30 log units) away from the limit.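

Compound 2 and compound 4 both carry limits rather than numbers, so no step can be read between them. The compounds shown leave open whether pyrrolidin-1-yl or cyclohexylamino gives stronger inhibition on the shared core.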